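Methoxy on the aromatic ring of compound 2

The source may report more compounds than this note shows. Statements on the series, on what has been measured and on what is new or still open speak of the compounds shown alone.

In a functional assay on MCF7 cells (Homo sapiens) for cytotoxicity, read by MTT assay, with a stated time of 96 h (on this read-out higher numbers stand for weaker inhibition and lower numbers for stronger inhibition), compound 2 `Cc1cc2c(c(=O)o1)C(c1ccccc1)C(C#N)=C(N)O2` gives 46000 nM. Compound 1 `Cc1cc2c(c(=O)o1)C(c1ccc(Br)cc1)C(C#N)=C(N)O2` gives 35000 nM, and these two numbers lie within the scatter of each other. Compound 3 `COc1ccc(C2C(C#N)=C(N)Oc3cc(C)oc(=O)c32)cc1` differs from compound 2 by methoxy in place of hydrogen on an aromatic carbon, with methoxy in place of hydrogen on an aromatic carbon. For the measured compounds named here, the only measured step at this carbon is a 1.3-fold higher number from compound 1 to compound 2 (0.12 log units; within the scatter), a single exchange of bromo for hydrogen. As far as these compounds go, because of a 1.3-fold higher number from compound 1 to compound 2 (0.12 log units; within the scatter) no step beyond the scatter is expected in this assay, though methoxy itself remains untested. The expected step is a 1.2-fold lower number from compound 2 to compound 3 (0.06 log units; within the scatter). Compound 3 is estimated at 40000 nM, with an expected range from 18000 nM to 85000 nM.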

Compound 3, half-maximal inhibitory concentration: 57000 nM
Beside the measured number, compound 3's estimate is 1.4-fold (0.15 log units) below it; low and high end bracket the measured number.
By their numbers in this assay, from the lowest: compounds 1, 2 and 3 (each within the scatter of the next).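

In this assay the exchange of hydrogen for methoxy gives a 1.2-fold higher number from compound 2 to compound 3 (0.09 log units; within the scatter) and the exchange of bromo for methoxy gives a 1.6-fold higher number from compound 1 to compound 3 (0.21 log units; within the scatter) at the same aromatic carbon, para to a large group. With hydrogen, bromo and methoxy now compared, this position still shows no step beyond the scatter. No supporting data bear on this result.

As far as these compounds go, whether an amine, a carboxylic acid or a longer chain at this carbon would produce a step beyond the scatter remains open. Also open, from the compounds shown here alone, is how changes elsewhere on the shared core would read.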